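Chalcone-capped quinolone amides against topoisomerase 1

The source may report more compounds than this note shows. Statements on the series, on what has been measured and on what is new or still open speak of the compounds shown alone.

Three compounds of the series carry a measurement in an assay on isolated protein for inhibition of DNA topoisomerase 1 (Homo sapiens), with a stated time of 30 min, tested at 100 uM; a higher number here means a stronger effect of the compound at the concentration tested, a lower number a weaker effect. Compound 1 `O=C(CN1CCN(c2cc3c(cc2F)c(=O)c(C(=O)O)cn3C2CC2)CC1)Nc1ccc(C(=O)/C=C/c2ccccc2)cc1` gives 57.2%. Compound 2 `O=C(CN1CCN(c2cc3c(cc2F)c(=O)c(C(=O)O)cn3C2CC2)CC1)Nc1ccc(C(=O)/C=C/c2cccc(Cl)c2)cc1` gives 68.8%, and compound 3 `COc1ccc(/C=C/C(=O)c2ccc(NC(=O)CN3CCN(c4cc5c(cc4F)c(=O)c(C(=O)O)cn5C4CC4)CC3)cc2)cc1` gives 67.6%. Compound 2 holds the highest of the three numbers; compound 3 sits nearest, a number 1.2 percentage points lower from compound 2 to compound 3 (within the scatter), while compound 1 sits furthest, a number 11.6 percentage points higher from compound 1 to compound 2 (beyond the scatter).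

Compound 4 `COc1ccc(/C=C/C(=O)c2ccc(NC(=O)CN3CCN(c4cc5c(cc4F)c(=O)c(C(=O)O)cn5C4CC4)CC3)cc2)cc1OC` is not yet measured. It differs from compound 2 by 3,4-dimethoxyphenyl in place of 3-chlorophenyl on a double-bonded chain carbon bound to a double-bonded chain carbon.

Among the measured compounds shown here, two measured steps bear on this change. The swap of the chlorine-bearing ring for the single-methoxy ring, a number 1.2 percentage points lower from compound 2 to compound 3 (within the scatter), was within the scatter, and the addition of one methoxy to the bare ring, a number 10.4 percentage points higher from compound 1 to compound 3 (beyond the scatter), was modest. For the measured compounds named here, no measured pair shows the effect of a second methoxy on the ring. On these grounds a step in this assay of about a number 0.8 percentage points lower from compound 2 to compound 4 (within the scatter) is expected, with no clear direction beyond the scatter. Compound 4 is therefore estimated at 68%, within a range of 57% to 79%.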

Compound 4, a percentage reported as inhibition, at one concentration (the size of the read-out at that concentration, not a potency): 73.2%
Estimate against measurement, compound 4: 5.2 percentage points below; the measured number falls inside the stated range.
By their numbers in this assay, from the lowest: compound 1; then compounds 3, 2 and 4 (each within the scatter of the next).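

In this assay, the second methoxy on the ring now has a measured pair (a number 5.6 percentage points higher from compound 3 to compound 4 (within the scatter)), and that step does not separate the 3,4-dimethoxyphenyl group from the single-methoxy ring. The exchange for 3-chlorophenyl also stays inside the scatter (a number 4.4 percentage points higher from compound 2 to compound 4 (within the scatter)), while the comparison with the bare phenyl ring is the one that clears it (a number 16 percentage points higher from compound 1 to compound 4 (beyond the scatter)), so at this position the three substituted rings read alike and only the unsubstituted ring stands apart. Nothing measured on these compounds accounts for that reading.

Still open, on these data alone, is how an amine or a carboxylic acid on this ring would read, or a longer chain on the oxygen in place of methyl. Also open, as far as these compounds go, is whether chloro and methoxy would add up on a single ring.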